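Swapping the amide substituent on a low-inhibition chromene

A few compounds are considered here, and "the series" means these few. Any claim that something is new, unique, unknown or untested is made for them only; others in the source may bear on it.

Compound 1: `COc1cccc2cc(C(=O)NC3CCCC3)c(=N)oc12`, 20%
Compound 2: `COCCNC(=O)c1cc2cc(Cl)ccc2oc1=N`, 13%

In an assay on HeLa cells for displacement of a labelled ligand from adenosine receptor A3 (Homo sapiens), read by scintillation counting, with a stated time of 180 min, tested at 10 uM (on this read-out higher numbers stand for more inhibition at the one concentration tested (going by the name of the read-out) and lower numbers for less inhibition), compound 1 gives 20%, and compound 2 gives 13%. Compound 2 has the lower of the two numbers, but the gap to compound 1 is within the scatter, so the two cannot be told apart.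

Compound 3 is `CCC(CO)NC(=O)c1cc2cc(Cl)ccc2oc1=N`. It differs from compound 2 in one place: 1-(hydroxymethyl)propyl in place of 2-methoxyethyl on an amide-type nitrogen. For the measured compounds named here, no measured pair shows what this kind of change does, so the expectation is for no step beyond the scatter in this assay. The step expected is a number 2 percentage points higher from compound 2 to compound 3 (within the scatter). Compound 3 is estimated at 15%, within 0% to 35%.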

Compound 3, a percentage reported as inhibition, at one concentration (the size of the read-out at that concentration, not a potency): 0%
Compound 3: the middle estimate sits 15 percentage points above what was measured, within the range that was stated.
By their numbers in this assay, from the lowest: compound 3; then compounds 2 and 1 (each within the scatter of the next).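

In this assay the amide-type nitrogen proves sensitive to its substituent: 1-(hydroxymethyl)propyl in place of 2-methoxyethyl gives a number 13 percentage points lower from compound 2 to compound 3 (beyond the scatter) on an otherwise unchanged compound. The earlier compounds shown here differ in more than one place, so they could not isolate this change. Nothing measured here explains the step.

The entering group gains a hydrogen-bond donor and a carbon, and these two differences remain tangled. A 2-hydroxyethyl group or a plain butyl chain at this nitrogen would help separate them.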